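Cytotoxicity notes on the aryl amide acid series

The compounds below may be only part of what the source reports. "The series", "measured", "known", "first", "only" and "open" are said of these compounds alone.

Measured in an ADME assay on HepG2 cells (Homo sapiens) for cytotoxicity, read by CellTiter-Glo and resazurin assay, with a stated time of 72 h; on this read-out higher numbers stand for an effect only at larger amounts of compound and lower numbers for an effect already at smaller amounts:
- compound 1, `CC(C)N(Cc1cccc(OCCCCCC(=O)O)c1)C(=O)c1ccc(-c2ccoc2)cc1`, gives > 26000 nM; this is a limit of the assay and not a number.
- compound 2, `CC(C)N(Cc1cccc(OCCCCCC(=O)O)c1)C(=O)c1ccc(-c2cccc(Oc3ccccc3)c2)cc1`, gives > 18700 nM; this is a limit of the assay and not a number.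
- compound 3, `CC(C)N(Cc1cccc(OCCCCCC(=O)O)c1)C(=O)c1ccc(-c2cc3ccccc3n2S(=O)(=O)c2ccccc2)cc1`, gives > 26000 nM; this is a limit of the assay and not a number.

Within the data shown here, compound 1 therefore stands at the limit of > 26000 nM in this assay, at which 2 of the 3 values shown sit, while one other member sits at the limit of > 18700 nM in this assay, at which 1 of the 3 values shown sits; no numerical cytotoxicity has been recorded for any compound of the set, and no step between measured compounds can be stated beyond what the limits show.

Compound 4, `CC(C)N(Cc1cccc(OCCCCCC(=O)O)c1)C(=O)c1ccc(-c2c[nH]c3ccccc23)cc1`, differs from compound 1 by 1H-indol-3-yl in place of furan-3-yl on an aromatic carbon. With every measured value sitting at a limit, no step beyond the scatter is expected from compound 1 to compound 4 in this assay, and the estimated step is a number no higher from compound 1 to compound 4 (the limit leaves the size open). Compound 4 is expected to give 26000 nM, with a range from 10000 nM to 60000 nM, and most likely the assay will again report only a limit.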

Compound 4, half-maximal effective concentration: > 26000 nM
Compound 4 ended at the assay's limit (the forecaster's own chance of this, stated with the estimate: 75%); the middle value lies on the limit itself.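

Compound 1 and compound 4 both sit at an assay limit in this assay, not at a number, and no step can be read for 1H-indol-3-yl in place of furan-3-yl. The compounds shown leave open at what concentration any member of the series affects these cells.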